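Chloro to hydrogen on the benzamide: expected effect

The compounds below may be only part of what the source reports. "The series", "measured", "known", "first", "only" and "open" are said of these compounds alone.

Measured compounds:
compound 1 `COc1ccc(CNC(=O)CSc2nc3ccc(NC(=O)c4ccc([N+](=O)[O-])cc4)cc3s2)cc1` — > 100000 nM
compound 2 `CNC(=O)CSc1nc2ccc(NC(=O)c3ccc(Cl)cc3)cc2s1` — 29400 nM
compound 3 `O=C(CSc1nc2ccc(NC(=O)c3ccc(Cl)cc3)cc2s1)NCc1ccc(Cl)cc1` — 29300 nM

All three were run in a functional assay on MCF7 cells (Homo sapiens) for cytotoxicity, read by MTT assay, with a stated time of 48 h; on this read-out higher numbers stand for weaker inhibition and lower numbers for stronger inhibition. For compound 1 the value is a limit of the assay and not a number (the limit of > 100000 nM in this assay, at which 1 of the 3 values shown sits). For the measured compounds named here, compound 3 holds the lowest of the two numbers, but its nearest neighbour compound 2 sits within the scatter, as the single one-place step shows: a 1.0-fold lower number from compound 2 to compound 3 (0.00 log units; within the scatter). That step changes the group on the saturated chain carbon bound to the amide-type nitrogen and leaves the other amide untouched.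

Compound 4 `O=C(CSc1nc2ccc(NC(=O)c3ccccc3)cc2s1)NCc1ccc(Cl)cc1` differs from compound 3 in that other amide: hydrogen in place of chloro on an aromatic carbon. Going by the values given here, no measured step touches this position, so there is nothing that speaks for a change in either direction. The expectation for compound 4 is therefore a step of about a 1.0-fold higher number from compound 3 to compound 4 (0.01 log units; within the scatter), nothing beyond the scatter. Compound 4 is estimated at 30000 nM, with a range from 10000 nM to 90000 nM.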

Compound 4, half-maximal inhibitory concentration: 33700 nM
Compound 4: the middle estimate sits 1.1-fold (0.05 log units) below what was measured, and the stated range covers the measured number.
By their numbers in this assay, from the lowest: compounds 3, 2 and 4 (each within the scatter of the next). At a limit, above all of these: compound 1.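

In this assay, for the compounds shown here, hydrogen in place of chloro on the benzamide ring gives a 1.2-fold higher number from compound 3 to compound 4 (0.06 log units; within the scatter) and provides the first reading at this position, since the earlier step changed only the other amide. With the rest of compound 3 kept, the chloro on this aromatic carbon, para to a large group, is therefore not required to keep the number within the scatter of compound 3. Nothing shown gives a cause for this small step.

Going by these compounds, whether an amine or a carboxylic acid at this same position would move the number beyond the scatter remains open. Also open, on these data alone, is whether a fluoro or a hydroxyl group here, with the rest of compound 4 unchanged, would separate from the chloro and hydrogen pair.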